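A few compounds are considered here, and "the series" means these few. Any claim that something is new, unique, unknown or untested is made for them only; others in the source may bear on it.

Compound 1 `COc1cc(/C=C/C(=O)/C=C(/C=C/c2ccc(O)c(OC)c2)NCCO)ccc1O`: 28300 nM
Compound 2 `COc1cc(/C=C/C2=CC(=O)CC(c3ccc(O)c(OC)c3)N2CCCO)ccc1O`: 33900 nM

In a functional assay, read by spectrophotometry, with a stated time of 30 min (a lower number here means that less compound is needed, a higher number that more compound is needed for the effect), compound 1 and compound 2 lie within the usual scatter of each other. Compound 3 `COc1cc(/C=C/C(=O)/C=C(/C=C/c2ccc(O)c(OC)c2)NCCCO)ccc1O` is not yet measured. It differs from compound 1 by hydroxymethyl in place of hydroxy on a saturated chain carbon, two bonds along the chain from an amine nitrogen. For the measured compounds named here, no measured pair shows this change, so the expectation in this assay is of no step beyond the scatter. The estimated step is a 1.1-fold higher number from compound 1 to compound 3 (0.03 log units; within the scatter). The estimated value for compound 3 is 30000 nM, with an expected range of 14000 nM to 65000 nM.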

Compound 3, half-maximal effective concentration in the functional assay: 27600 nM
For compound 3 the middle estimate is 1.1-fold (0.04 log units) above the measured one; measured number inside the range.
By their numbers in the functional assay, from the lowest: compounds 3, 1 and 2 (each within the scatter of the next).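

For the compounds shown here, the earlier compounds offered no pair differing in one place, so this is the first direct reading of this chain carbon, two bonds along the chain from an amine nitrogen. In the functional assay, the step for hydroxymethyl in place of hydroxy is a 1.0-fold lower number from compound 1 to compound 3 (0.01 log units; within the scatter). In a physicochemical assay for solubility, using the shake flask method, in phosphate buffer, with a stated time of 24 h, at pH 6.8 (a lower number here means a less soluble compound, a higher number a more soluble compound), compound 1 gives 11800 nM and compound 3 gives 56300 nM. The same change moves the number beyond the scatter: the measured solubility of compound 1, 11800 nM, and of compound 3, 56300 nM, a 4.8-fold higher number (0.68 log units; beyond the scatter).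

A single pair gives no trend along the chain. As far as these compounds go, whether a longer chain, or an amine or a carboxylic acid at the chain end, would hold the number in the functional assay and shift the number in the physicochemical assay remains open.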